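This account rests on a few compounds, and the source may have more. Where it says the series, first, only, none or still open, it means among the compounds named here.

In a functional assay on MGC-803 cells (Homo sapiens) for inhibition, read by MTT assay, with a stated time of 48 h (on this read-out higher numbers stand for weaker inhibition and lower numbers for stronger inhibition), compound 1 `COc1ccc(-c2coc3cc(OCCCBr)ccc3c2=O)cc1` gives 64900 nM, and compound 2 `CCN1CCN(C(=S)SCCCOc2ccc3c(=O)c(-c4ccc(OC)cc4)coc3c2)CC1` gives 54000 nM. Among the measured compounds shown here, compound 2 therefore holds the lower of only two numbers, but the gap is no real separation: the one measured step is a 1.2-fold lower number from compound 1 to compound 2 (0.08 log units; within the scatter). Compound 3 `COc1ccc(-c2coc3cc(OCCCSC(=S)N4CCN(C(=O)OC(C)(C)C)CC4)ccc3c2=O)cc1` departs from compound 2 at a single place, with tert-butoxycarbonyl in place of ethyl on an amine nitrogen in a ring. For the measured compounds named here, no measured pair changes this group directly, so the evidence is indirect. The nearest guide is compound 2 itself, where installing the whole group that carries this nitrogen produced only a 1.2-fold lower number from compound 1 to compound 2 (0.08 log units; within the scatter). On that single step, no shift beyond the scatter is expected in this assay, and no direction can be favoured with any confidence, although a small drift to a lower number is allowed for. The range is kept wide because the evidence is one step. The expected change is a 1.2-fold lower number from compound 2 to compound 3 (0.08 log units; within the scatter). Compound 3 is estimated at 45000 nM, with an expected range from 15000 nM to 100000 nM.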

Compound 3, half-maximal inhibitory concentration: 6070 nM
The estimate for compound 3 lay 7.4-fold (0.87 log units) above the measured number, outside the stated range (below it).
By their numbers in this assay, from the lowest: compound 3; then compounds 2 and 1 (each within the scatter of the next).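

In this assay the amine nitrogen in the ring proves to be a place where the number can move: tert-butoxycarbonyl in place of ethyl gives an 8.9-fold lower number from compound 2 to compound 3 (0.95 log units; beyond the scatter) and so lies beyond the scatter. The earlier step, a 1.2-fold lower number from compound 1 to compound 2 (0.08 log units; within the scatter), stayed within the scatter, so the presence of the whole ring-bearing group had shown no separation, whereas the group carried on this nitrogen does make a difference between compound 2 and compound 3. The entering group brings more heavy atoms, a double bond outside aromatic rings and hydrogen-bond acceptors that ethyl lacks, but no measurement here says which of these features, if any, accounts for the result.

The compounds shown leave open whether the lower number belongs to the carbonyl, to the oxygen that follows it or to the tert-butyl end of the entering group. From the compounds shown here alone, an acetyl group, a plain tert-butyl group or a free amine on this same nitrogen would separate these parts, and whether the step holds with a longer chain elsewhere in the molecule also remains untested by these three compounds.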